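Naphthyl glycosides: removal of a ring methoxy

The source may hold more compounds than are shown below. What is called first, only, known or untested is meant among the compounds shown, and "the series" means these compounds.

Measured so far:
compound 1 `O[C@@H]1CO[C@@H](Oc2ccc3ccccc3c2)C[C@H]1O`, 19 uM
compound 2 `CO[C@H]1[C@H](Oc2ccc3ccccc3c2)OC[C@@H](O)[C@@H]1O`, 55 uM
compound 3 `CO[C@@H]1[C@@H](O)[C@H](Oc2ccc3ccccc3c2)OC[C@H]1O`, 17 uM

All three were read in an ADME assay on CCD-1095SK cells (Homo sapiens) for antiproliferative activity, read by crystal violet staining, with a stated time of 96 h; a lower number here means that less compound is needed, a higher number that more compound is needed for the effect. Compound 2 and compound 3 have the same atoms joined differently; the difference between the two cores is not broken down here. Compound 1 and compound 3 lie within the scatter of each other. The change from compound 2 to compound 1 is hydrogen in place of methoxy on a saturated ring carbon, and it gave a 2.9-fold lower number from compound 2 to compound 1 (0.46 log units; beyond the scatter).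

Compound 4 `O[C@@H]1CO[C@@H](Oc2ccc3ccccc3c2)[C@H](O)C1` is not yet measured. It differs from compound 3 by hydrogen in place of methoxy on a saturated ring carbon. This is the same kind of change as that from compound 2 to compound 1, but its surroundings differ: here the carbon sits next to two ring atoms that each bear a hydroxy group, two ring bonds from the ring atom that bears a large group and three ring bonds from the ring oxygen, whereas before it sat next to the ring atom that bears a hydroxy group and next to the ring atom that bears a large group, two ring bonds from the ring oxygen. For the measured compounds named here, with only one earlier step of this kind, the expectation for compound 4 in this assay is a step of a 1.7-fold lower number from compound 3 to compound 4 (0.23 log units; within the scatter), set a little smaller than the earlier one because compound 3 already gives 17 uM. The estimate for compound 4 is 10 uM, between 4 uM and 30 uM.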

Compound 4, concentration for half-maximal effect: 79 uM
The estimate for compound 4 lay 7.9-fold (0.90 log units) below the measured number; measured number above the stated range.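

In this assay, hydrogen in place of methoxy on a saturated ring carbon gave a 4.6-fold higher number from compound 3 to compound 4 (0.67 log units; beyond the scatter). The change therefore cannot be carried from one core to the other as a fixed increment, and the two steps run in opposite directions: the same change on two cores in this assay, a 2.9-fold lower number (0.46 log units; beyond the scatter) from compound 2 to compound 1 and a 4.6-fold higher number (0.67 log units; beyond the scatter) from compound 3 to compound 4, 13-fold (1.13 log units) apart, beyond the scatter of two such steps

This rests on a single pair of steps, and it does not show which difference between the two cores sets the direction, nor whether the same reversal would appear on any other core in this series.

Going by these compounds, it remains open how an amine or a longer ether chain in place of the methoxy would behave on either core. A carboxylic acid at the same carbon is equally unresolved.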